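A few compounds are considered here, and "the series" means these few. Any claim that something is new, unique, unknown or untested is made for them only; others in the source may bear on it.

Measured compounds:
- compound 1, `O=C(NCCCCN1CCN(c2cccc3[nH]c(=O)[nH]c23)CC1)c1ccc2ccccc2c1`: 158 nM
- compound 2, `Cc1cccc(N2CCN(CCCCNC(=O)c3ccc4ccccc4c3)CC2)c1C`: 230 nM

Both were tested in an assay on isolated protein for displacement of a labelled ligand from Alpha-1A adrenergic receptor (Homo sapiens); on this read-out higher numbers stand for weaker inhibition and lower numbers for stronger inhibition. Within the data shown here, compound 2 has the higher of the two numbers, but the only step between them, a 1.5-fold higher number from compound 1 to compound 2 (0.16 log units; within the scatter), lies within the scatter, so the two values cannot be told apart on this read-out.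

Compound 3, `O=C(NCCCCN1CCN(c2ccccc2Cl)CC1)c1ccc2ccccc2c1`, differs from compound 2 in one place: 2-chlorophenyl in place of 2,3-dimethylphenyl on an amine nitrogen in a ring. Among the measured compounds shown here, the one measured step that bears on this swap is the exchange of the aryl group on the same ring nitrogen, a 1.5-fold higher number from compound 1 to compound 2 (0.16 log units; within the scatter), which changed the number by no more than the scatter. A further change of the same aryl group is therefore expected to move the number little, and in no clear direction.

The expected step is a 1.2-fold lower number from compound 2 to compound 3 (0.06 log units; within the scatter), within the scatter.

Compound 3 is thus estimated to give 200 nM in this assay, with a likely range from 60 nM to 700 nM.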

Compound 3, inhibition constant: 29.9 nM
For compound 3 the middle estimate is 6.7-fold (0.83 log units) above the measured one; the whole stated range lies above it.
By their numbers in this assay, from the lowest: compound 3; then compounds 1 and 2 (each within the scatter of the next).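

In this assay, among these compounds, the group on the amine nitrogen in a ring proves able to shift the number beyond the scatter, which the first pair of compounds did not show. Placing 2-chlorophenyl there instead of 2,3-dimethylphenyl gives a clear gain (a 7.7-fold lower number from compound 2 to compound 3 (0.89 log units; beyond the scatter)), and the same group also improves on the larger group of 10 heavy atoms (a 5.3-fold lower number from compound 1 to compound 3 (0.72 log units; beyond the scatter)). The data offer no measured explanation for why this group gives the lowest number of the three.

Going by these compounds, it remains open whether the gain goes with the chlorine itself or with the loss of the methyl groups. A plain phenyl, 2-methylphenyl or 2-fluorophenyl group on the same nitrogen would help to tell these two readings apart.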